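The source may report more compounds than this note shows. Statements on the series, on what has been measured and on what is new or still open speak of the compounds shown alone.

Compound 1 `C=C(c1ccc(OC)cc1NC(=O)CO)c1ccc(OC)c2c1OC(C)(C)C=C2`: 40 nM; compound 2 `C=C(c1cc(OC)c(OC)c(OC)c1)c1ccc(OC)cc1NC(=O)CO`: 20 nM.

For the measured compounds named here, in a functional assay on A549 cells (Homo sapiens) for antiproliferative activity, read by MTT assay, with a stated time of 48 h (a lower number here means a stronger inhibitor, a higher number a weaker inhibitor), compound 1 gives 40 nM, the higher of the two numbers measured so far; compound 2 gives 20 nM, and the gap between the two lies within the scatter. Compound 3 `C=C(c1ccc(OC)cc1NC(=O)CNCC)c1ccc(OC)c2c1OC(C)(C)C=C2` differs from compound 1 in one place: ethylamino in place of hydroxy on a saturated chain carbon bound to a carbonyl carbon. Going by the values given here, no pair of measured compounds shows this change, so its effect is unknown here. Compound 3 is expected to behave much like compound 1, with a 1.3-fold higher number from compound 1 to compound 3 (0.10 log units; within the scatter) as an estimated step that may not exceed the scatter. The estimate for compound 3 is 50 nM, ranging from 15 nM to 170 nM.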

Compound 3, half-maximal inhibitory concentration: 970 nM
Compound 3: the middle estimate sits 19-fold (1.29 log units) below what was measured; the measured number lies above the stated range.
By their numbers in this assay, from the lowest: compounds 2 and 1 (each within the scatter of the next); then compound 3.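

In this assay, the place on a saturated chain carbon bound to a carbonyl carbon proves sensitive: ethylamino in place of hydroxy gives a 24-fold higher number from compound 1 to compound 3 (1.38 log units; beyond the scatter) even though both groups count the same hydrogen-bond donors and acceptors and neither carries a net charge. For the compounds shown here, the earlier compounds held no such change, so this is the first sign that the hydroxy cannot be freely exchanged on the core of compound 1. Nothing measured here explains the loss. Still open, from the compounds shown here alone, is whether a smaller amine such as methylamino, a longer chain or a carboxylic acid at this place would stay nearer compound 1, and whether ethylamino costs as much on the core of compound 2.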